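Ring Size at the Ester Oxygen: From Cyclopentyl to Cyclohexyl

The source may report more compounds than this note shows. Statements on the series, on what has been measured and on what is new or still open speak of the compounds shown alone.

Measured so far:
- compound 1 `CCCOC(=O)C1=C(C)NC(=O)NC1c1ccco1`: 3%
- compound 2 `CC1=C(C(=O)OC2CCCC2)C(c2ccco2)NC(=O)N1`: 14%

In an assay on membranes from HeLa cells for displacement of a labelled ligand from adenosine receptor A3 (Homo sapiens), read by scintillation counting, with a stated time of 180 min, tested at 1 uM (on this read-out lower numbers stand for less inhibition and higher numbers for more inhibition at the one concentration tested (going by the name of the read-out)), compound 2 gives the highest of the two numbers, with compound 1 the nearest, a number lower by a number 11 percentage points higher from compound 1 to compound 2 (beyond the scatter). Compound 3 `CC1=C(C(=O)OC2CCCCC2)C(c2ccco2)NC(=O)N1` differs from compound 2 in one place: cyclohexyl in place of cyclopentyl on an oxygen next to a carbonyl group. Within the data shown here, the only step that bears on this is the one from compound 1 to compound 2, where a number 11 percentage points higher from compound 1 to compound 2 (beyond the scatter); it changed the same oxygen next to a carbonyl group and was modest. A step of similar size, upward, is expected here, namely a number 8 percentage points higher from compound 2 to compound 3 (within the scatter). For compound 3 the estimate is 22%, between 6% and 40%.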

Compound 3, a percentage reported as inhibition, at one concentration (the size of the read-out at that concentration, not a potency): 4%
Beside the measured number, compound 3's estimate is 18 percentage points above it; the measured number lies below the stated range.
By their numbers in this assay, from the lowest: compounds 1, 3 and 2 (each within the scatter of the next, the first and the last beyond it).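

In this assay the data give a number 10 percentage points lower from compound 2 to compound 3 (within the scatter), where cyclohexyl replaces cyclopentyl, and a number 1 percentage points higher from compound 1 to compound 3 (within the scatter), where it replaces propyl; both changes sit on an oxygen next to a carbonyl group. So having a carbon ring on this oxygen does not by itself carry over the step seen with cyclopentyl: cyclohexyl cannot be told apart from either of the other two groups, even though those two differ beyond the scatter. Nothing at hand explains this result. On these data alone, whether a benzyl group or a longer chain such as hexyl on this oxygen would stand clearly apart from these three remains open.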